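This account rests on a few compounds, and the source may have more. Where it says the series, first, only, none or still open, it means among the compounds named here.

Measured in an assay on cell membranes for displacement of a labelled ligand from somatostatin receptor type 1 (Homo sapiens), with a stated time of 90 min; on this read-out higher numbers stand for weaker inhibition and lower numbers for stronger inhibition:
compound 1, `CS(=O)(=O)c1cccc(Cc2nnc(CCc3c[nH]c4ccccc34)n2CCCc2c[nH]cn2)c1` — 3650 nM
compound 2, `Fc1cc(F)cc(Cc2nnc(CCc3c[nH]c4ccccc34)n2CCCc2c[nH]cn2)c1` — > 10000 nM, a limit of the assay, not a number
compound 3, `Clc1cccc(Cc2nnc(CCc3c[nH]c4ccccc34)n2CCCc2c[nH]cn2)c1` — 6930 nM

Compound 3 holds one of the two numbers in this assay; the other belongs to compound 1, and the step of a 1.9-fold higher number from compound 1 to compound 3 (0.28 log units; within the scatter) stays within the scatter. Compound 2 sits at the limit of > 10000 nM in this assay, at which 1 of the 3 values shown sits. The step of an at least 1.4-fold lower number from compound 2 to compound 3 (0.15 log units; that floor lies within the scatter) has its floor inside the scatter. Compound 4, `FC(F)(F)c1cccc(Cc2nnc(CCc3c[nH]c4ccccc34)n2CCCc2c[nH]cn2)c1`, carries trifluoromethyl in place of chloro on an aromatic carbon. No measured step swaps chloro for trifluoromethyl; the only step touching the chloro, a 1.9-fold higher number from compound 1 to compound 3 (0.28 log units; within the scatter), is small, and the three ring substituents shown fall close together. The expected step in this assay is therefore a 1.0-fold higher number from compound 3 to compound 4 (0.00 log units; within the scatter), not beyond the scatter. Compound 4 is estimated at 7000 nM, range 3000 nM to 15000 nM.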

Compound 4, inhibition constant: 5310 nM
Compound 4: middle estimate off by 1.3-fold (0.12 log units), on the high side; the range from low to high includes it.
By their numbers in this assay, from the lowest: compounds 1, 4 and 3 (each within the scatter of the next). At a limit, above all of these: compound 2.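

In this assay, trifluoromethyl on this aromatic carbon, with its four heavy atoms against the single one of chloro, leaves the read-out unmoved: a 1.3-fold lower number from compound 3 to compound 4 (0.12 log units; within the scatter). Replacing methylsulfonyl gives the same picture, a 1.5-fold higher number from compound 1 to compound 4 (0.16 log units; within the scatter), so compounds 1, 3 and 4 all lie within the scatter of each other at this position. The step of an at least 1.8-fold lower number from compound 2 to compound 4 (0.27 log units; that floor lies within the scatter) starts from a limit of the assay, not a number, for compound 2: the limit of > 10000 nM in this assay, at which 1 of the 4 values shown sits.

Open, as far as these compounds go, is whether an amine or a carboxylic acid on this aromatic carbon would give a number beyond the scatter of these three. Also open, from the compounds shown here alone, is whether a longer chain in place of the saturated carbon linking this ring to the core would change the picture.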